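The compounds below may be only part of what the source reports. "The series", "measured", "known", "first", "only" and "open" are said of these compounds alone.

Measured so far in a functional assay on HT cells (Homo sapiens) for antiproliferative activity, read by fluorescence, with a stated time of 72 h; on this read-out higher numbers stand for weaker inhibition of growth and lower numbers for stronger inhibition of growth:
compound 1, `CC(C)c1n[nH]c2c(NCc3ccc(-c4ccccn4)cc3)nc(SCC(O)CN)nc12`, giving 55 nM
compound 2, `CC(O)CSc1nc(NCc2ccc(-c3ccccn3)cc2)c2[nH]nc(C(C)C)c2n1`, giving 62 nM
compound 3, `CC(C)c1n[nH]c2c(NCc3ccc(-c4ccccn4)cc3)nc(SCCn3ccnc3)nc12`, giving 155 nM

Compound 3 has the highest number of the three. Its nearest neighbour is compound 2, from which it lies a 2.5-fold higher number from compound 2 to compound 3 (0.40 log units; beyond the scatter), and its furthest is compound 1, from which it lies a 2.8-fold higher number from compound 1 to compound 3 (0.45 log units; beyond the scatter); both steps are beyond the scatter, so compound 3 is the weakest inhibitor among the three measured. Between compound 1 and compound 2 the step is a 1.1-fold higher number from compound 1 to compound 2 (0.05 log units; within the scatter).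

Compound 4, `CC(C)c1n[nH]c2c(NCc3ccc(-c4ccccn4)cc3)nc(SCCNC(N)=O)nc12`, has not been measured. It differs from compound 3 by ureido in place of 1H-imidazol-1-yl on a saturated chain carbon, two bonds along the chain from a sulfur.

The two steps that bear on this are those into compound 3, where (1H-imidazol-1-yl)methyl took the place of 2-amino-1-hydroxyethyl or 1-hydroxyethyl and the number rose modestly each time. Compound 4 removes the 1H-imidazol-1-yl again and puts in ureido, a group with hydrogen-bond donors as in compounds 1 and 2. On that basis the number is expected to come back down, by a modest step, toward compounds 1 and 2 rather than past them. Compound 4 is therefore expected to give about 80 nM, in the range 35 nM to 200 nM. This estimate corresponds to an expected 1.9-fold lower number from compound 3 to compound 4 (0.29 log units; within the scatter).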

Compound 4, concentration for 50% growth inhibition: 240 nM
The estimate for compound 4 lay 3.0-fold (0.48 log units) below the measured number; the measured number lies above the stated range.
By their numbers in this assay, from the lowest: compounds 1 and 2 (each within the scatter of the next); then compounds 3 and 4 (each within the scatter of the next).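

In this assay, ureido in place of 1H-imidazol-1-yl on this saturated chain carbon, two bonds along the chain from a sulfur, gives a 1.5-fold higher number from compound 3 to compound 4 (0.19 log units; within the scatter) and so leaves the two compounds unresolved, even though an aromatic ring has given way to an open group that carries hydrogen-bond donors. Against the hydroxy-bearing chains, ureidomethyl in place of 1-hydroxyethyl gives a 3.9-fold higher number from compound 2 to compound 4 (0.59 log units; beyond the scatter) and ureidomethyl in place of 2-amino-1-hydroxyethyl gives a 4.4-fold higher number from compound 1 to compound 4 (0.64 log units; beyond the scatter) with both steps printed as modest, so the gap seen with the imidazole persists with ureido, and hydrogen-bond donors on the chain do not by themselves place a compound with compounds 1 and 2 in this small set. Nothing at hand explains why the chains of compounds 1 and 2 stand apart from those of compounds 3 and 4.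

Still open, as far as these compounds go, is whether the hydroxyl group itself accounts for that gap, which a simple amine or a carboxylic acid on the same saturated chain carbon would help to test. From the compounds shown here alone, it is also open whether a longer chain bearing ureido would stay with compounds 3 and 4 or move toward compounds 1 and 2.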